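A few compounds are considered here, and "the series" means these few. Any claim that something is new, unique, unknown or untested is made for them only; others in the source may bear on it.

In a functional assay on MDA-MB-231 cells (Homo sapiens) for inhibition, read by MTT assay, with a stated time of 48 h (on this read-out higher numbers stand for weaker inhibition of growth and lower numbers for stronger inhibition of growth), compound 1 `CC(C)c1ccc(Nc2ncnc3ccc(NC(=S)NCc4ccccc4)cc23)cc1` gives 12800 nM and compound 2 `S=C(NCc1ccccc1)Nc1ccc2ncnc(Nc3ccc(-c4ccccc4)cc3)c2c1` gives 8400 nM. Among the compounds with values here, these are the only two numbers available, and they lie within the usual scatter of each other, so compound 2 cannot be ranked against compound 1.

Compound 3 `S=C(NCc1ccccc1)Nc1ccc2ncnc(Nc3ccc(Oc4ccccc4)cc3)c2c1` matches compound 2 except for one group: phenoxy in place of phenyl on an aromatic carbon, para to a large group (phenoxy in place of phenyl on an aromatic carbon).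

Within the data shown here, only one measured step bears on this change. It is a 1.5-fold lower number from compound 1 to compound 2 (0.18 log units; within the scatter), where phenyl took the place of isopropyl on an aromatic carbon, and it lies within the scatter. Among the measured compounds shown here, this is a thin guide, since it is a single step and a different swap, and no measurement yet shows how phenoxy behaves. On the strength of that one small step, no shift beyond the scatter is expected in this assay, and the range is kept wide.

The estimated step is a 1.1-fold lower number from compound 2 to compound 3 (0.02 log units; within the scatter). Compound 3 is expected to give about 8000 nM, with an estimated range from 3500 nM to 18000 nM.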

Compound 3, concentration for 50% growth inhibition: 6800 nM
Compound 3: middle estimate off by 1.2-fold (0.07 log units), on the high side; measured number inside the range.
By their numbers in this assay, from the lowest: compounds 3, 2 and 1 (each within the scatter of the next).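

The swap of phenyl for phenoxy, on an aromatic carbon para to a large group, adds one oxygen and one hydrogen-bond acceptor, and in this assay it comes with a 1.2-fold lower number from compound 2 to compound 3 (0.09 log units; within the scatter). Phenoxy in place of isopropyl at the same carbon gives a 1.9-fold lower number from compound 1 to compound 3 (0.27 log units; within the scatter), so isopropyl, phenyl and phenoxy now all stand within the scatter of one another, and none of the three can be ranked above another at this position. No measurement is at hand that could explain these small steps.

As far as these compounds go, what remains open is whether a group of a different kind on this carbon, such as an amine, a carboxylic acid or a single fluorine atom, would move the number beyond the scatter in this assay. The three compounds also share their benzyl group and the rest of the core, so they do not show what a longer chain or another change away from this carbon would do.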